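Swapping the ring on the piperazine nitrogen: cyclohexyl to pyrazinyl

The source may hold more compounds than are shown below. What is called first, only, known or untested is meant among the compounds shown, and "the series" means these compounds.

Measured so far:
Compound 1, `Nc1ccccc1NC(=O)c1ccc(CSC(=S)N2CCN(c3cccnc3)CC2)cc1`, gives 72.5% in a functional assay on HeLa cells (Homo sapiens) for antiproliferative activity, read by CCK-8 assay, with a stated time of 72 h, tested at 8 uM; on this read-out lower numbers stand for a weaker effect and higher numbers for a stronger effect at the one concentration tested.
Compound 2, `Nc1ccccc1NC(=O)c1ccc(CSC(=S)N2CCN(C3CCCCC3)CC2)cc1`, gives 76.1% in this assay.

Among the measured compounds shown here, compound 2 holds the higher of the two numbers, but its only neighbour is compound 1, and the step of a number 3.6 percentage points higher from compound 1 to compound 2 (within the scatter) lies within the scatter, so the two compounds cannot be told apart on this read-out. That single step is also the only one that bears on the change now in question, since it exchanges the same position between an aromatic heterocycle and a saturated carbon ring.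

Compound 3, `Nc1ccccc1NC(=O)c1ccc(CSC(=S)N2CCN(c3cnccn3)CC2)cc1`, differs from compound 2 as follows: pyrazin-2-yl in place of cyclohexyl on an amine nitrogen in a ring. This returns the position to an aromatic ring with ring nitrogens, as in compound 1, where the step to compound 2 was small. The expected step of a number 3.1 percentage points lower from compound 2 to compound 3 (within the scatter) is therefore no larger than the scatter and, if anything, points slightly down toward the value of compound 1.

For compound 3 in this assay the estimated value is 73%, with a range from 60% to 84%.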

Compound 3, a percentage reported as inhibition, at one concentration (the size of the read-out at that concentration, not a potency): 76.9%
Compound 3: middle estimate off by 3.9 percentage points, on the low side; the range from low to high includes it.
By their numbers in this assay, from the lowest: compounds 1, 2 and 3 (each within the scatter of the next).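

With compound 3, this position on the ring amine nitrogen has carried a saturated carbon ring and two different aromatic rings with ring nitrogens, and this assay does not tell them apart. Among the compounds shown here, replacing cyclohexyl, with 0 hydrogen-bond acceptors, by pyrazin-2-yl, with 2, gives a number 0.8 percentage points higher from compound 2 to compound 3 (within the scatter) and so adds a second comparison between a saturated and an aromatic ring to the one the first two compounds offered. The new direct comparison of the two aromatic rings gives a number 4.4 percentage points higher from compound 1 to compound 3 (within the scatter) and shows that replacing pyridin-3-yl by pyrazin-2-yl also leaves the read-out within the scatter, although no measurement here offers an explanation for this lack of separation.

All three groups are six-membered rings, so these compounds do not show whether a small methyl group, a benzyl group or a longer alkyl chain at this position would give a different read-out. Since each compound is reported at a single concentration, they also leave open whether the three would still match if their effects were compared at other concentrations.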